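A Carboxy Group at the Position Where Methyl Mattered

The source may report more compounds than this note shows. Statements on the series, on what has been measured and on what is new or still open speak of the compounds shown alone.

Of the compounds shown here, two share one core and have been measured in an assay on HEK293 cells for agonist activity at transient receptor potential cation channel subfamily M member 8 (Homo sapiens), read by fluorescence and calcium flux, with a stated time of 15 min; on this read-out higher numbers stand for an effect only at larger amounts of compound and lower numbers for an effect already at smaller amounts. Compound 1 `CCN(Cc1cccs1)C(=O)COc1ccc(C)cc1` carries a methyl on the aromatic ring, and in this assay compound 1 gives 8 nM. Compound 2 `CCN(Cc1cccs1)C(=O)COc1ccccc1` lacks that methyl, and in this assay compound 2 gives 1400 nM, the highest number among the two measured compounds. Going by the values given here, the single measured step, a 180-fold higher number from compound 1 to compound 2 (2.24 log units; beyond the scatter), shows that the ring position is sensitive to what sits there.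

Compound 3 `CCN(Cc1cccs1)C(=O)COc1ccc(C(=O)O)cc1` differs from compound 2 by carboxy in place of hydrogen on an aromatic carbon. Among the compounds with values here, no measured step involves a carboxy group, so the effect of this change is not covered directly; the only related step is the one from compound 1 to compound 2, which concerns the same position but a different group. Given that compound 2 already stands at 1400 nM, an effect in the direction of a still higher number, or no step beyond the scatter, is expected. Compound 3 is estimated at 10000 nM, with a likely range from 2000 nM to 50000 nM, a step of a 7.1-fold higher number from compound 2 to compound 3 (0.85 log units; beyond the scatter) being expected.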

Compound 3, half-maximal effective concentration: "not active" (no number reported)
Nothing numeric was reported for compound 3; no gap can be computed for the estimate.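

Compound 3 is recorded as "not active" (no number reported) in this assay, so no step can be read between compound 2 and compound 3. No available evidence bears on this result. The compounds shown leave open how far compound 3 lies from compound 2, and whether any group other than methyl at this position gives a low number.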